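Cytotoxicity notes: dichlorophenyl swap in the styrylquinoline amides

The source may hold more compounds than are shown below. What is called first, only, known or untested is meant among the compounds shown, and "the series" means these compounds.

Measured so far:
compound 1 `O=C(CNc1ccccc1)NCCNc1cc(/C=C/c2ccccc2)nc2ccccc12`: 7800 nM
compound 2 `O=C(CNc1ccccc1)NCCCCNc1cc(/C=C/c2ccccc2)nc2ccccc12`: 3300 nM
compound 3 `O=C(CNc1ccc(Cl)cc1Cl)NCCNc1cc(/C=C/c2ccccc2)nc2ccccc12`: > 50000 nM

In an ADME assay on J774 cells (Mus musculus) for cytotoxicity, read by MTT assay, with a stated time of 48 h (on this read-out higher numbers stand for weaker inhibition and lower numbers for stronger inhibition), compound 1 gives 7800 nM and compound 2 gives 3300 nM. The difference between the cores of compound 1 and compound 2 is not broken down here. Compound 3 sits at the limit of this assay, not at a number, with > 50000 nM.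

The change from compound 1 to compound 3 is 2,4-dichlorophenyl in place of phenyl on an amine nitrogen. That step, an at least 6.4-fold higher number from compound 1 to compound 3 (0.80 log units; beyond the scatter), is known only as a lower bound because of the limit of > 50000 nM in this assay, at which 1 of the 3 values shown sits.

Compound 4 `O=C(CNc1ccc(Cl)cc1Cl)NCCCCNc1cc(/C=C/c2ccccc2)nc2ccccc12` is not yet measured. Its relation to compound 2 is 2,4-dichlorophenyl in place of phenyl on an amine nitrogen, the same change as that from compound 1 to compound 3, made at the same kind of place on the same amine nitrogen. Going by the values given here, with only one earlier instance, the expectation rests on the single step of an at least 6.4-fold higher number from compound 1 to compound 3 (0.80 log units; beyond the scatter) applied to the value of compound 2, 3300 nM. On that basis compound 4 is expected to give 25000 nM, somewhere between 9000 nM and 60000 nM, a step of roughly a 7.6-fold higher number from compound 2 to compound 4 (0.88 log units; beyond the scatter) from compound 2. Because the earlier step ended at the limit of > 50000 nM in this assay, at which 1 of the 3 values shown sits, there is a fair chance that compound 4 will also be reported only as a limit in this assay.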

Compound 4, half-maximal inhibitory concentration: 7300 nM
For compound 4 the middle estimate is 3.4-fold (0.53 log units) above the measured one; measured number below the stated range.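

In this assay, 2,4-dichlorophenyl in place of phenyl on the amine nitrogen again raises the number, with a 2.2-fold higher number from compound 2 to compound 4 (0.34 log units; beyond the scatter), but the size of the step does not carry over unchanged from one core to the other: the same change on two cores in this assay, an at least 6.4-fold higher number (0.80 log units; beyond the scatter) from compound 1 to compound 3 and a 2.2-fold higher number (0.34 log units; beyond the scatter) from compound 2 to compound 4, at least 2.8-fold (0.46 log units) apart, beyond the scatter of two such steps

Compound 3 is reported only as a limit, > 50000 nM, so the step on the core of compound 1 and the gap between the two steps are known only as lower bounds. The two pairs therefore show a shared direction with a core-dependent size, but they do not show why the size differs, and they cannot predict the size of the step on any further core.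

As far as these compounds go, it remains open whether the same direction would hold with a longer chain between the amide and the amine nitrogen on the shared core, and whether the size of the step would move further with that chain. From the compounds shown here alone, it is also open how a chlorophenyl group with a single chlorine, a methoxyphenyl group or a carboxyphenyl group would compare with 2,4-dichlorophenyl at the same place on each of the two cores.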